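The source may hold more compounds than are shown below. What is called first, only, known or untested is meant among the compounds shown, and "the series" means these compounds.

Of the compounds shown here, two built on one shared core have been measured. In a functional assay on A549 cells (Homo sapiens) for antiproliferative activity, read by spectrophotometry, with a stated time of 2 days (on this read-out higher numbers stand for weaker inhibition of growth and lower numbers for stronger inhibition of growth), compound 1 `CN(c1cccc2c1CN(c1nc(Nc3ccc(Nc4ccccc4)cc3)ncc1C(F)(F)F)C2)S(C)(=O)=O` gives 6200 nM, while compound 2 `CN(c1cccc2c1CN(c1nc(Nc3cccc(Oc4ccccc4)c3)ncc1C(F)(F)F)C2)S(C)(=O)=O` gives 19000 nM, the higher of the two numbers and beyond the scatter from compound 1. Compound 3 `CN(c1cccc2c1CN(c1nc(Nc3cccc(C(F)(F)F)c3)ncc1C(F)(F)F)C2)S(C)(=O)=O` differs from compound 2 in one place: trifluoromethyl in place of phenoxy on an aromatic carbon, the trifluoromethyl sitting on an aromatic carbon of a six-membered aromatic ring of carbon only, meta to a large group. Among the compounds with values here, no measured pair shows this exchange, so the expected step of a 1.6-fold lower number from compound 2 to compound 3 (0.20 log units; within the scatter) is small, toward a lower number but possibly within the scatter. Compound 3 is estimated at 12000 nM, with a range from 4000 nM to 36000 nM.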

Compound 3, concentration for 50% growth inhibition: > 30000 nM
Compound 3 was reported as a limit (the forecaster's own chance of this, stated with the estimate: 10%); at least 2.5-fold (0.39 log units) between middle value and limit.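

In this assay compound 3 gives > 30000 nM, which is a limit and not a number. Trifluoromethyl in place of phenoxy gives an at least 1.5-fold higher number from compound 2 to compound 3 (0.19 log units; that floor lies within the scatter), so no gain in growth inhibition appears at this position, while a real loss remains unproved. The true size of the step stays unknown because the reading stands at a limit: the limit of > 30000 nM in this assay, at which 1 of the 3 values shown sits.

Going by these compounds, whether a methoxy group, an amine or a carboxylic acid here would shift the read-out remains open. So does whether the ring or the oxygen of phenoxy matters more, as this exchange removes both at once.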